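This account rests on a few compounds, and the source may have more. Where it says the series, first, only, none or still open, it means among the compounds named here.

Three compounds with a shared core have numbers in an assay on HEK293 cells for positive allosteric modulation of metabotropic glutamate receptor 5 (Homo sapiens), read by FLIPR (a lower number here means that less compound is needed, a higher number that more compound is needed for the effect), so far. Compound 1, with the structure `O=C(C1CCC(F)(F)CC1)N1CC(c2nc(-c3cccc(F)c3)no2)C1`, gives 520 nM in this assay. Compound 3, with the structure `O=C(N1CCCCC1)N1CC(c2nc(-c3cccc(Cl)c3)no2)C1`, gives 370 nM, the lowest number of the two that are numbers, and its distance to compound 1 lies within the scatter, so the two cannot be ranked against each other. Compound 2, with the structure `O=C(c1ccccc1F)N1CC[C@H]1c1nc(-c2cccc(F)c2)no1`, is reported only as a limit of the assay, > 10000 nM, and not as a number (the limit of > 10000 nM in this assay, at which 1 of the 3 values shown sits).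

Compound 4, with the structure `O=C(c1ccccc1F)N1CC(c2nc(-c3cccc(Cl)c3)no2)C1`, has not yet been measured. It is reached from compound 3 by the change (2-fluorophenyl in place of piperidin-1-yl on a carbonyl carbon). For the measured compounds named here, no measured pair shows this kind of change, so no measured step tells what to expect; the comparisons on hand are only the number of compound 3 and the limit of compound 2, which carries a 2-fluorophenyl on a carbonyl carbon but differs from compound 4 in more than one place.

With that little to go on, the step of a 1.4-fold higher number from compound 3 to compound 4 (0.13 log units; within the scatter) is expected to stay close to none beyond the scatter. Compound 4 is estimated at 500 nM in this assay, within a range from 120 nM to 2500 nM.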

Compound 4, half-maximal effective concentration: > 10000 nM
Compound 4: only a limit was reported; the forecaster's own chance of this, stated with the estimate: 15%; at least 20-fold (1.30 log units) between middle value and limit.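

Replacing piperidin-1-yl with 2-fluorophenyl on the carbonyl carbon, with the rest of the molecule unchanged, gives an at least 27-fold higher number from compound 3 to compound 4 (1.43 log units; beyond the scatter). For the compounds shown here, this is the first single-place change available here, and it shows that the group on this carbonyl carbon can decide whether a compound gives a measurable number in this assay, even though the two groups are close in size and neither has hydrogen-bond donors or acceptors by the count. The step is only a lower bound on the true difference, because compound 4 is reported as a limit of the assay and not as a number: the limit of > 10000 nM in this assay, at which 2 of the 4 values shown sit.

One pair cannot tell whether the ring's aromatic character, its fluorine or the missing ring nitrogen goes with this step, and a plain phenyl, a cyclohexyl or a morpholin-4-yl on the same carbonyl carbon would help to separate these. On these data alone, it also remains open whether piperidin-1-yl would give a similar number on the shared core with a different group in place of the chlorine-bearing ring.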